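The compounds below may be only part of what the source reports. "The series", "measured", "known", "first", "only" and "open" are said of these compounds alone.

Working notes on the series, read in a functional assay on MCF7 cells (Homo sapiens) for antiproliferative activity, read by MTT assay; on this read-out lower numbers stand for stronger inhibition and higher numbers for weaker inhibition:

- compound 1 `COc1cc2c(Oc3ccc(NC(=O)Nc4ccccc4F)cc3)ccnc2cc1OCCCCCCC(=O)NO`: 660 nM
- compound 2 `COc1cc2c(Oc3ccc(NC(=O)Nc4ccc(C)cc4C)cc3)ccnc2cc1OCCCCCCC(=O)NO`: 3430 nM
- compound 3 `COc1cc2c(Oc3ccc(NC(=O)NC4CCCCC4)cc3)ccnc2cc1OCCCCCCC(=O)NO`: 600 nM

Compound 3 stands at the low end of these numbers. The nearest step to it is a 1.1-fold lower number from compound 1 to compound 3 (0.04 log units; within the scatter), and the furthest is a 5.7-fold lower number from compound 2 to compound 3 (0.76 log units; beyond the scatter).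

The next change gives compound 4 `COc1cc2c(Oc3ccc(NC(=O)N/N=C/c4ccccc4)cc3)ccnc2cc1OCCCCCCC(=O)NO`: a group of 8 heavy atoms (7 carbon, 1 nitrogen; one six-membered aromatic ring of carbon only) in place of a group of 6 heavy atoms (6 carbon; one six-membered non-aromatic ring of carbon only), on an amide-type nitrogen. A group of 8 heavy atoms replaces the cyclohexyl on the amide-type nitrogen.

Going by the values given here, all the measured steps concern this same nitrogen. The step of a 5.2-fold higher number from compound 1 to compound 2 (0.72 log units; beyond the scatter) shows that two groups with an aromatic ring can lie far apart, so the ring alone sets no clear expectation. Among the compounds with values here, no measured compound carries the entering group, and the data do not show what its extra nitrogen and double bond do. As the measured steps stay modest or smaller, a modest move towards a higher number is expected, although no step beyond the scatter remains possible.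

The expected step is a 2.0-fold higher number from compound 3 to compound 4 (0.30 log units; within the scatter).

The estimate for compound 4 is 1200 nM, with an expected range of 450 nM to 3500 nM.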

Compound 4, half-maximal inhibitory concentration: 610 nM
Compound 4: the middle estimate sits 2.0-fold (0.29 log units) above what was measured, and the stated range covers the measured number.
By their numbers in this assay, from the lowest: compounds 3, 4 and 1 (each within the scatter of the next); then compound 2.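

In this assay, the entering group, with its extra nitrogen and its double bond outside aromatic rings, sits level with both the cyclohexyl group (a 1.0-fold higher number from compound 3 to compound 4 (0.01 log units; within the scatter)) and the 2-fluorophenyl group (a 1.1-fold lower number from compound 1 to compound 4 (0.03 log units; within the scatter)). Set against the 2,4-dimethylphenyl group, it gives a step beyond the scatter (a 5.6-fold lower number from compound 2 to compound 4 (0.75 log units; beyond the scatter)), so groups carrying a six-membered aromatic ring on this amide-type nitrogen again lie apart, while three quite different groups now share one level. No measurement at hand accounts for this level or for the gap to the 2,4-dimethylphenyl group.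

Going by these compounds, whether a phenyl group with a single methyl would stay at this level remains open. So does the effect of a benzyl group or a plain butyl chain on this nitrogen.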